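A few compounds are considered here, and "the series" means these few. Any claim that something is new, unique, unknown or untested is made for them only; others in the source may bear on it.

Of the compounds shown here, three that share one core have been tested so far in a functional assay on MOLT-3 cells (Homo sapiens); on this read-out lower numbers stand for stronger inhibition and higher numbers for weaker inhibition. Compound 1 `CCCCSC[C@H](NC(C)=O)C(=O)CCl` gives 5600 nM. Compound 2 `CCCCCSC[C@H](NC(C)=O)C(=O)CCl` gives 5400 nM, and compound 3 `CCCCCCCCCSC[C@H](NC(C)=O)C(=O)CCl` gives 6700 nM. The change from the first to the second of these is methyl in place of hydrogen on a saturated chain carbon, four bonds along the chain from a sulfur, and it produced a 1.0-fold lower number from compound 1 to compound 2 (0.02 log units; within the scatter). The two cores compared below differ as follows: pentyl in place of hydrogen on a saturated chain carbon, four bonds along the chain from a sulfur. That step came out as a 1.2-fold higher number from compound 1 to compound 3 (0.08 log units; within the scatter), and the remaining pair shows a 1.2-fold higher number from compound 2 to compound 3 (0.09 log units; within the scatter), so all three values sit together.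

Compound 4 `CCCCCCCCCCSC[C@H](NC(C)=O)C(=O)CCl` is not yet measured. It differs from compound 3 by methyl in place of hydrogen on a saturated chain carbon, nine bonds along the chain from a sulfur. Going by the values given here, this is the same kind of change as the one from compound 1 to compound 2, although the place differs: there the new methyl sat four bonds along the chain from a sulfur, here it sits nine bonds along the chain from a sulfur. The expected step is a 1.0-fold higher number from compound 3 to compound 4 (0.02 log units; within the scatter), because the earlier step of a 1.0-fold lower number from compound 1 to compound 2 (0.02 log units; within the scatter) stayed within the scatter. Compound 4 is therefore estimated at 7000 nM, with a range from 3500 nM to 14000 nM.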

Compound 4, half-maximal inhibitory concentration: 3400 nM
Estimate against measurement, compound 4: 2.1-fold (0.31 log units) above; measured number outside the range, below it.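

In this assay, methyl in place of hydrogen gave a 2.0-fold lower number from compound 3 to compound 4 (0.29 log units; within the scatter), while the pentyl and hexyl changes gave a 1.6-fold lower number from compound 2 to compound 4 (0.20 log units; within the scatter) and a 1.6-fold lower number from compound 1 to compound 4 (0.22 log units; within the scatter), so none of these steps can be told apart from repeat-measurement noise. The methyl change can be set beside its earlier counterpart, and the two steps show no real difference between the cores, even though the position along the chain differs: the same change on two cores in this assay, a 1.0-fold lower number (0.02 log units; within the scatter) from compound 1 to compound 2 and a 2.0-fold lower number (0.29 log units; within the scatter) from compound 3 to compound 4, 1.9-fold (0.28 log units) apart, within the scatter of two such steps The pentyl change reads the same way, which means these results are consistent with such a change carrying over from one core to another, but they do not show that it has the same effect everywhere, as steps this small could hide a modest real difference: the same change on two cores in this assay, a 1.2-fold higher number (0.08 log units; within the scatter) from compound 1 to compound 3 and a 1.6-fold lower number (0.20 log units; within the scatter) from compound 2 to compound 4, 1.9-fold (0.28 log units) apart, within the scatter of two such steps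

All the compounds shown carry a plain saturated chain on the sulfur. They leave open whether a much longer chain, or a chain ending in an amine or a carboxylic acid, would shift the number beyond the scatter.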